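Changing the Group on the Carbonyl Carbon of Compound 2

A few compounds are considered here, and "the series" means these few. Any claim that something is new, unique, unknown or untested is made for them only; others in the source may bear on it.

In a functional assay on HepG2 cells (Homo sapiens) for antiproliferative activity, read by MTT assay, with a stated time of 48 h (a higher number here means a weaker inhibitor, a lower number a stronger inhibitor), compound 1 `CCOC(=O)C(CC(=O)OC)NC(=O)c1ccc(C(CC)(CC)c2ccc(OCCC(O)(CC)CC)c(C)c2)n1CC` gives > 50000 nM, which is a limit of the assay and not a number. For the measured compounds named here, compound 2 `CCC(C)C(NC(=O)c1ccc(C(CC)(CC)c2ccc(OCCC(O)(CC)CC)c(C)c2)n1CC)C(=O)O` gives 2620 nM, the only actual number so far. Compound 3 `CCn1c(C(=O)N(C)CC(=O)O)ccc1C(CC)(CC)c1ccc(OCCC(O)(CC)CC)c(C)c1` has not yet been measured. It differs from compound 2 by (carboxymethyl)(methyl)amino in place of (1-carboxy-2-methylbutyl)amino on a carbonyl carbon. Going by the values given here, only one measured step bears on this change: an at least 19-fold lower number from compound 1 to compound 2 (1.28 log units; beyond the scatter). That large step, beyond the scatter, shows that the group at this end of the molecule can matter, but it does not test this exchange, so the direction remains uncertain. A moderate weakening is expected in this assay, with an estimated 2.7-fold higher number from compound 2 to compound 3 (0.43 log units; beyond the scatter). Compound 3 is estimated at 7000 nM, with an expected range of 1800 nM to 35000 nM.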

Compound 3, half-maximal inhibitory concentration: 5710 nM
The estimate for compound 3 lay 1.2-fold (0.09 log units) above the measured number; low and high end bracket the measured number.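

In this assay, a 2.2-fold higher number from compound 2 to compound 3 (0.34 log units; beyond the scatter) shows that this position on the carbonyl carbon still gives a measurable number when (1-carboxy-2-methylbutyl)amino gives way to the smaller (carboxymethyl)(methyl)amino, at the price of a modest weakening. an at least 8.7-fold lower number from compound 1 to compound 3 (0.94 log units; beyond the scatter) shows that compound 3, like compound 2, stands clear of compound 1, so two different groups that each carry a free carboxy group now read stronger than the group in compound 1. The size of that step remains only a bound, since compound 1 stands at a limit of the assay: the limit of > 50000 nM in this assay, at which 1 of the 3 values shown sits.

The compounds shown do not separate the loss of the longer side chain from the gain of the methyl on nitrogen, as both change together. They also leave open how a primary amide in place of the carboxylic acid would read at this position.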